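The compounds below may be only part of what the source reports. "The series", "measured", "known", "first", "only" and "open" are said of these compounds alone.

Of the compounds shown here, two of one series have been measured in a functional assay on CRL2813 cells (Homo sapiens) for cytotoxicity, read by sulforhodamine B assay, with a stated time of 5 days; on this read-out higher numbers stand for weaker inhibition and lower numbers for stronger inhibition. Compound 1 `O=C(Nc1ccc(I)cc1)N[C@H]1CC[C@H](Oc2ccc(F)cc2)CC1` gives 10200 nM in this assay, and compound 2 `O=C(Nc1ccc(F)cc1)N[C@H]1CC[C@H](Oc2ccc(F)cc2)CC1` gives 20000 nM. For the measured compounds named here, the only measured step, a 2.0-fold higher number from compound 1 to compound 2 (0.29 log units; within the scatter), places compound 2 at the higher of the two numbers, though the gap to compound 1 lies within the scatter. Compound 3 `O=C(Nc1ccc(Br)cc1)N[C@H]1CC[C@H](Oc2ccc(F)cc2)CC1` differs from compound 2 by bromo in place of fluoro on an aromatic carbon. The step from compound 1 to compound 2 bears directly on this change, since it also exchanged one halogen for another at the same place, and its size was within the scatter. Compound 3 is therefore expected to sit between compound 2 and compound 1, with a step of a 1.5-fold lower number from compound 2 to compound 3 (0.19 log units; within the scatter) that is not expected to exceed the scatter. The estimated value for compound 3 in this assay is 13000 nM, with a range from 5000 nM to 35000 nM.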

Compound 3, half-maximal inhibitory concentration: > 20000 nM
Compound 3: no number, only a limit; the forecaster's own chance of this, stated with the estimate: 5%; at least 1.5-fold (0.18 log units) between middle value and limit.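

In this assay compound 3 gives > 20000 nM, which is a limit of the assay and not a number. The change from fluoro to bromo on this aromatic carbon gives a number no lower from compound 2 to compound 3 (the limit leaves the size open), so this change has no size, and that step cannot be read: the limit of > 20000 nM in this assay, at which 1 of the 3 values shown sits. The change from iodo to bromo at the same place gives an at least 1.9-fold higher number from compound 1 to compound 3 (0.29 log units; that floor lies within the scatter), so no halogen exchange at this position has yet shown a step beyond the scatter.

As far as these compounds go, how far compound 3 actually lies from compound 1 and compound 2 stays open. Also open, from the compounds shown here alone, is how the value would respond at this position to a group that is not a halogen, such as an amine, a methoxy group or a carboxylic acid.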